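The source may hold more compounds than are shown below. What is called first, only, known or untested is meant among the compounds shown, and "the series" means these compounds.

Measured compounds:
compound 1 `O=c1c2cnn(-c3ccc(F)cc3)c2ncn1CC1(O)CCN(Cc2c(Cl)cccc2Cl)CC1` — "not determined" (no result reported) in an assay on Sf21 cells for inhibition of ubiquitin carboxyl-terminal hydrolase 7 (Homo sapiens), read by spectrophotometry, with stated times of 30 min and 2 h; on this read-out higher numbers stand for weaker inhibition and lower numbers for stronger inhibition
compound 2 `O=c1c2cnn(-c3ccc(F)cc3)c2ncn1CC1(O)CCN(Cc2ccc(F)cc2Cl)CC1` — 1600 nM

Compound 1 carries a 2,6-dichlorobenzyl group on the piperidine nitrogen, but for it no number came out of this assay, so it gives nothing to compare against. Compound 2, with a 2-chloro-4-fluorobenzyl group in the same position, gives 1600 nM in this assay and therefore stands as the only number shown here; with no second value there is no step between measured compounds to speak of.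

Compound 3 `COC(=O)c1ccc(CN2CCC(O)(Cn3cnc4c(cnn4-c4ccc(F)cc4)c3=O)CC2)c(Cl)c1` is the next compound to be measured. It differs from compound 2 in one place: methoxycarbonyl in place of fluoro on an aromatic carbon. Among the measured compounds shown here, since no step in this assay has yet been measured for a change of this kind, the size of the step from compound 2 to compound 3 can only be guessed, and the expectation is a step of a 1.1-fold lower number from compound 2 to compound 3 (0.03 log units; within the scatter), which stays within the usual scatter of the assay rather than pointing clearly in either direction. On that basis compound 3 is expected to give about 1500 nM in this assay, with a likely range from 500 nM to 5000 nM.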

Compound 3, half-maximal inhibitory concentration: 800 nM
Compound 3: middle estimate off by 1.9-fold (0.27 log units), on the high side, and the stated range covers the measured number.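

In this assay, putting methoxycarbonyl in place of fluoro on this aromatic carbon gives a 2.0-fold lower number from compound 2 to compound 3 (0.30 log units; within the scatter). Among the compounds shown here, with only one number available before, nothing was known about changing this position; now it is clear that this carbon, meta to a chloro group and para to a large group, can carry a group of four heavy atoms with two hydrogen-bond acceptors instead of a single fluorine, and the result stays within the normal variation between repeated measurements. No measurement shown here explains why the two compounds cannot be told apart, so the pair establishes only that this exchange is tolerated in this assay, not how the new group acts.

The compounds shown leave open whether a carboxylic acid, a primary amide or an aminomethyl group on the same carbon would shift the number beyond that variation, and whether a longer ester such as ethoxycarbonyl would behave like methoxycarbonyl. They also leave open what happens when the chloro group is replaced by another atom or group, such as methyl or bromo, since both compounds with a number keep it.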